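This account rests on a few compounds, and the source may have more. Where it says the series, first, only, none or still open, it means among the compounds named here.

Compound 2 `COC(=O)c1c[nH]c([C@@H](O)c2ccccc2)cc1=O` is the starting point. In a functional assay on K562 cells (Homo sapiens) for inhibition, read by sulforhodamine B assay, with a stated time of 48 h (a lower number here means a stronger inhibitor, a higher number a weaker inhibitor), compound 2 gives > 50000 nM, which is a limit of the assay rather than a measured number. Compound 1 `NC(=O)c1c[nH]c([C@@H](O)c2ccccc2)cc1=O` gives > 50000 nM in this assay, again a limit. The step that the two limits leave unreadable from compound 1 to compound 2 therefore cannot be read, because both values sit at the limit of > 50000 nM in this assay, at which 2 of the 2 values shown sit. Compound 3 `CC(C)CC(=O)NC(=O)c1c[nH]c([C@@H](O)c2ccccc2)cc1=O` differs from compound 2 in one place: (isobutylcarbonyl)amino in place of methoxy on a carbonyl carbon. Within the data shown here, no measured step bears on this change, so in this assay no shift beyond the scatter is expected. Compound 3 is estimated at 60000 nM, between 20000 nM and 200000 nM, an expected step that the limit leaves unreadable from compound 2 to compound 3.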

Compound 3, half-maximal inhibitory concentration: > 50000 nM
Compound 3: no number, only a limit; the forecaster's own chance of this, stated with the estimate: 85%; the middle value is on the limit's open side.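

No new step can be read between compound 1, compound 2 and compound 3, because all three values are limits rather than numbers: (the limit of > 50000 nM in this assay, at which 3 of the 3 values shown sit). The compounds shown leave open whether any change to the shared core gives a measurable value in this assay at all.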